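The source may report more compounds than this note shows. Statements on the series, on what has been measured and on what is new or still open speak of the compounds shown alone.

Working notes on the series. In an assay for inhibition of acid-sensing ion channel 3 (Homo sapiens), read by patch clamp, tested at 20 uM (a higher number here means more inhibition at the concentration tested (going by the name of the read-out), a lower number less inhibition), compound 2 `NC(N)=NC(=O)c1nc(Cl)c(NC2CCCCC2)nc1N` gives 92%. Compound 1 `NC(N)=NC(=O)c1nc(Cl)c(NCc2cccc(F)c2)nc1N` gives 90% in this assay, a number within the scatter of that of compound 2, so the two stand together and no order between them is read. Compound 3 `NC(N)=NC(=O)c1nc(Cl)c(NCC2CCCCC2)nc1N` is the next entry for this assay. The change from compound 2 to compound 3 is cyclohexylmethyl in place of cyclohexyl on a nitrogen on an aromatic ring. Since compound 1, which also carries a one-carbon link to its ring, gives 90%, the step from compound 2 to compound 3 is expected to be a number 3 percentage points lower from compound 2 to compound 3 (within the scatter), nothing beyond the scatter. Compound 3 is therefore estimated at 89%, in the range 72% to 98%.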

Compound 3, a percentage reported as inhibition, at one concentration (the size of the read-out at that concentration, not a potency): 96%
Estimate against measurement, compound 3: 7 percentage points below; the measured number falls inside the stated range.
By their numbers in this assay, from the lowest: compounds 1, 2 and 3 (each within the scatter of the next).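

In this assay, the position on the nitrogen on an aromatic ring accepts cyclohexylmethyl as well as cyclohexyl, with a number 4 percentage points higher from compound 2 to compound 3 (within the scatter) showing that the one-carbon link leaves the two compounds together. With that link present, the ring can be cyclohexyl or 3-fluorophenyl, with a number 6 percentage points higher from compound 1 to compound 3 (within the scatter) again leaving the two compounds together. Nothing available accounts for either step.

Among the compounds shown here, since no step here goes beyond the scatter, what this position will not accept remains open. A longer chain such as cyclohexylethyl, a small methyl group, or a carboxylic acid on the cyclohexyl ring could still separate from these compounds.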